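Amino at the six-membered ring of compound 1

The source may hold more compounds than are shown below. What is called first, only, known or untested is meant among the compounds shown, and "the series" means these compounds.

Measured so far:
compound 1 `COc1ncnc2c1c(-c1cccs1)cn2[C@@H]1O[C@H](CO)[C@@H](O)[C@H]1O`: 1760 nM
compound 2 `COc1ncnc2c1c(-c1ccco1)cn2[C@@H]1O[C@H](CO)[C@@H](O)[C@H]1O`: 1020 nM
compound 3 `CNc1ncnc2c1c(-c1cccs1)cn2[C@@H]1O[C@H](CO)[C@@H](O)[C@H]1O`: > 20000 nM

Compound 1 stands highest of the two numbers; the nearest is compound 2 with a 1.7-fold lower number from compound 1 to compound 2 (0.24 log units; within the scatter). Compound 3 gives only a limit in a functional assay on HeLa S3 cells (Homo sapiens) for antiproliferative activity, read by XTT assay, with a stated time of 72 h (a higher number here means a weaker inhibitor, a lower number a stronger inhibitor), (the limit of > 20000 nM in this assay, at which 1 of the 3 values shown sits), so for compound 3 the number is not known. Compound 4 `COc1nc(N)nc2c1c(-c1cccs1)cn2[C@@H]1O[C@H](CO)[C@@H](O)[C@H]1O` is not yet measured. It differs from compound 1 by amino in place of hydrogen on an aromatic carbon, on an aromatic carbon between two ring nitrogen atoms, meta to a methoxy group. Going by the values given here, no measured step touches this position. Among the compounds with values here, the only step that bears on the six-membered ring is an at least 11-fold higher number from compound 1 to compound 3 (1.05 log units; beyond the scatter), a large loss when the methoxy itself is changed; a 1.7-fold lower number from compound 1 to compound 2 (0.24 log units; within the scatter) concerns the five-membered aryl group and is within the scatter. The shared core therefore tolerates little change at the six-membered ring, but an added amino group leaves the methoxy in place. A weakening beyond the scatter is expected, though smaller than that seen for compound 3. For compound 4 the expected step is a 2.8-fold higher number from compound 1 to compound 4 (0.45 log units; beyond the scatter), giving an estimated 5000 nM with a range from 1500 nM to 20000 nM.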

Compound 4, half-maximal inhibitory concentration: > 20000 nM
Compound 4: only a limit was reported; the forecaster's own chance of this, stated with the estimate: 20%; at least 4.0-fold (0.60 log units) between middle value and limit.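

In this assay compound 4 gives > 20000 nM, which is a limit and not a number. Amino in place of hydrogen on an aromatic carbon, with the methoxy group left in place, gives an at least 11-fold higher number from compound 1 to compound 4 (1.05 log units; beyond the scatter), so this carbon between two ring nitrogen atoms is itself sensitive, and loss on the six-membered aromatic ring is not confined to changing the methoxy group. How far the loss extends cannot be read from this result: the limit of > 20000 nM in this assay, at which 2 of the 4 values shown sit.

Going by these compounds, whether this carbon accepts anything other than hydrogen stays open, for instance a methyl group or a chlorine atom, which would show whether the loss is particular to amino. Also open, on these data alone, is whether amino here has the same outcome with furan-2-yl in place of thiophen-2-yl.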